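The source may hold more compounds than are shown below. What is called first, only, known or untested is meant among the compounds shown, and "the series" means these compounds.

Compound 3, `CCCn1c(=O)[nH]c2nc(-c3ccc(S(=O)(=O)N4CCN(c5ccc(C)cc5)CC4)cc3)[nH]c2c1=O`, stands second highest of the three values in an assay on CHO cells for displacement of a labelled ligand from adenosine receptor A1 (Homo sapiens), read by scintillation counting, with a stated time of 90 min, tested at 1 uM, in the presence of a further agent that is not named here (a lower number here means less inhibition, a higher number more inhibition at the concentration tested (going by the name of the read-out)), giving 12%. Compound 1, `CCCn1c(=O)[nH]c2nc(-c3ccc(S(=O)(=O)N4CCN(c5cccc(Cl)c5)CC4)cc3)[nH]c2c1=O`, gives 21%, and compound 2, `CCCn1c(=O)[nH]c2nc(-c3ccc(S(=O)(=O)N4CCN(c5cccc(Br)c5)CC4)cc3)[nH]c2c1=O`, gives -1%. The two steps into compound 3 read a number 9 percentage points lower from compound 1 to compound 3 (within the scatter) and a number 13 percentage points higher from compound 2 to compound 3 (beyond the scatter). Compound 4, `CCCn1c(=O)[nH]c2nc(-c3ccc(S(=O)(=O)N4CCN(c5ccc(I)cc5)CC4)cc3)[nH]c2c1=O`, differs from compound 3 by iodo in place of methyl on an aromatic carbon. Among the measured compounds shown here, no measured step exchanges methyl for a halogen; the only step among halogens is a number 22 percentage points lower from compound 1 to compound 2 (beyond the scatter), in which the number fell. Given that a halogen exchange lowered the number once, and that compound 2 sits lowest, a modest drop is expected, a number 7 percentage points lower from compound 3 to compound 4 (within the scatter), though it may stay within the scatter. Compound 4 is therefore estimated at 5%, in the range -15% to 25%.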

Compound 4, a percentage reported as inhibition, at one concentration (the size of the read-out at that concentration, not a potency): 24%
Beside the measured number, compound 4's estimate is 19 percentage points below it; the measured number falls inside the stated range.
By their numbers in this assay, from the lowest: compound 2; then compounds 3, 1 and 4 (each within the scatter of the next, the first and the last beyond it).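

In this assay, among the compounds shown here, iodo in place of methyl on this aromatic carbon, para to a large group, raises the number (a number 12 percentage points higher from compound 3 to compound 4 (beyond the scatter)), whereas the only earlier step among halogens lowered it. The 4-iodophenyl compound also stands clear of the 3-bromophenyl one (a number 25 percentage points higher from compound 2 to compound 4 (beyond the scatter)) but not of the 3-chlorophenyl one (a number 3 percentage points higher from compound 1 to compound 4 (within the scatter)), so the three halogen-bearing compounds do not share one level. As far as these compounds go, whether an amine, a methoxy group or a carboxylic acid on this carbon would read nearer to iodo or to methyl stays open. Nothing at hand gives a reason for these steps.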